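This account rests on a few compounds, and the source may have more. Where it says the series, first, only, none or still open, it means among the compounds named here.

Among the measured compounds shown here, compound 1 `O=C1c2cc(COc3ccccc3)nn2CCN1c1ccc(F)c(F)c1` gives 81% in a functional assay on HEK293 cells for positive allosteric modulation of metabotropic glutamate receptor 5 (Homo sapiens), read by calcium flux (on this read-out higher numbers stand for larger maximal responses and lower numbers for smaller maximal responses), the higher of the two numbers measured so far; compound 2 `COc1ccc(N2CCn3nc(COc4ccccc4)cc3C2=O)cc1` gives 58%, a step of a number 23 percentage points lower from compound 1 to compound 2 (beyond the scatter) on an amide-type nitrogen in a ring. Compound 3 `O=C1c2cc(COc3ccccc3)nn2CCN1c1ccc(F)cn1` differs from compound 1 as follows: 5-fluoropyridin-2-yl in place of 3,4-difluorophenyl on an amide-type nitrogen in a ring. For the measured compounds named here, the measured step of a number 23 percentage points lower from compound 1 to compound 2 (beyond the scatter) concerns the same position but a different entering ring; no measured step covers a six-membered aromatic ring with 1 hetero atom and 1 hydrogen-bond acceptor there, so a modest decrease or no change beyond the scatter is expected in this assay. Compound 3 is estimated at 70%, between 50% and 90%, an expected step of a number 11 percentage points lower from compound 1 to compound 3 (beyond the scatter).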

Compound 3, largest response reached (Emax), in percent of the reference or control that the assay uses: 72%
Estimate against measurement, compound 3: 2 percentage points below; the measured number falls inside the stated range.
By their numbers in this assay, from the lowest: compound 2; then compounds 3 and 1 (each within the scatter of the next).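

At the amide-type nitrogen in a ring, a six-membered aromatic ring with a hetero atom and a hydrogen-bond acceptor is tolerated in this assay: replacing 3,4-difluorophenyl with 5-fluoropyridin-2-yl gives a number 9 percentage points lower from compound 1 to compound 3 (within the scatter). Replacing 4-methoxyphenyl with the same group gives a number 14 percentage points higher from compound 2 to compound 3 (beyond the scatter), so the lower response of compound 2 is not shared by every change away from 3,4-difluorophenyl. Nothing available explains these differences.

Open, from the compounds shown here alone, is how a plain pyridin-2-yl group or a pyrimidin-2-yl group would read at this nitrogen, which would show whether the response stays when the fluorine is gone or a second ring nitrogen enters.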